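Chromone carboxamides: methoxy analogue of compound 1

The source may hold more compounds than are shown below. What is called first, only, known or untested is meant among the compounds shown, and "the series" means these compounds.

Measured so far:
compound 1, `O=C(NCCC1CCN(Cc2ccccc2)CC1)c1coc2ccccc2c1=O`, 35300 nM
compound 2, `O=C(NCCC1CCN(Cc2ccccc2)CC1)c1coc2ccc(OCc3ccccc3)cc2c1=O`, 272 nM
compound 3, `O=C(NCCC1CCN(Cc2ccccc2)CC1)c1coc2ccc(Br)cc2c1=O`, 26100 nM

Compound 1 gives the highest number of the three in an assay on isolated protein for inhibition of Amine oxidase [flavin-containing] B (Homo sapiens), read by fluorescence and Amplex Red, with stated times of 15 min and 20 min; on this read-out lower numbers stand for stronger inhibition and higher numbers for weaker inhibition; its nearest neighbour is compound 3, and the gap a 1.4-fold lower number from compound 1 to compound 3 (0.13 log units; within the scatter) is within the scatter, so no order can be read between them. Compound 2 lies furthest away, with a 130-fold lower number from compound 1 to compound 2 (2.11 log units; beyond the scatter).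

Compound 4, `COc1ccc2c(=O)c(C(=O)NCCC3CCN(Cc4ccccc4)CC3)coc2c1`, differs from compound 1 by methoxy in place of hydrogen on an aromatic carbon. The same aromatic carbon carries the benzyloxy of compound 2 and the bromo of compound 3, so both steps from compound 1 bear on it: a 130-fold lower number from compound 1 to compound 2 (2.11 log units; beyond the scatter), a large move, and a 1.4-fold lower number from compound 1 to compound 3 (0.13 log units; within the scatter), no move beyond the scatter. The methoxy is neither of these two groups, and the two steps disagree widely, so the expectation for compound 4 is placed between them and nearer the bromo case, leaning toward a lower number because of a 130-fold lower number from compound 1 to compound 2 (2.11 log units; beyond the scatter).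

For compound 4 the expected step is a 4.4-fold lower number from compound 1 to compound 4 (0.64 log units; beyond the scatter), giving an estimate of 8000 nM with a range from 1500 nM to 35000 nM.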

Compound 4, half-maximal inhibitory concentration: 30900 nM
Beside the measured number, compound 4's estimate is 3.9-fold (0.59 log units) below it; the measured number falls inside the stated range.
By their numbers in this assay, from the lowest: compound 2; then compounds 3, 4 and 1 (each within the scatter of the next).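

In this assay, methoxy in place of hydrogen gives a 1.1-fold lower number from compound 1 to compound 4 (0.06 log units; within the scatter), so a group of two heavy atoms attached through oxygen leaves the number within the scatter, as bromo does with a 1.4-fold lower number from compound 1 to compound 3 (0.13 log units; within the scatter). An oxygen on this aromatic ring is therefore not enough to produce a large step, and among the substituted compounds shown only compound 2 departs from compound 1, with a 130-fold lower number from compound 1 to compound 2 (2.11 log units; beyond the scatter). Nothing at hand accounts for this difference between the methoxy and benzyloxy compounds.

As far as these compounds go, it remains open how much of the benzyloxy step would survive in an ethoxy, a phenoxy or a longer chain ending in a phenyl ring. Also open, from the compounds shown here alone, is whether the carbon bearing methoxy in compound 4 would respond to benzyloxy as compound 2 does.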